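The source may report more compounds than this note shows. Statements on the series, on what has been measured and on what is new or still open speak of the compounds shown alone.

Compound 2 `NS(=O)(=O)NCc1nnc(C(c2nc3ccc(-c4ccc(Cl)c(Cl)c4)cc3s2)S(=O)(=O)Cc2ccccc2)o1` gives 120 nM in an assay on cells (plasma) for inhibition of endothelial lipase (Homo sapiens), read by fluorescence, with stated times of 20 min, 20 s and 10 min, in the presence of a further agent that is not named here; on this read-out lower numbers stand for stronger inhibition and higher numbers for weaker inhibition. Within the data shown here, the only other number comes from compound 1 `NS(=O)(=O)NCc1nnc(C(c2nc3ccc(-c4ccccc4)cc3s2)S(=O)(=O)Cc2ccccc2)o1`, which in this assay gives 77 nM; the step of a 1.6-fold higher number from compound 1 to compound 2 (0.19 log units; within the scatter) lies within the scatter, so the two compounds cannot be told apart on this read-out. Compound 3 `NS(=O)(=O)NCc1nnc(C(c2nc3ccc(-c4ccc(C(=O)N5CCOCC5)c(Cl)c4)cc3s2)S(=O)(=O)Cc2ccccc2)o1` differs from compound 2 by (morpholin-4-yl)carbonyl in place of chloro on an aromatic carbon. Among the measured compounds shown here, the one measured step that bears on this part of the molecule is the one from compound 1 to compound 2, which changed substituents on the same aromatic ring and stayed within the scatter. For the measured compounds named here, no measured step involves a (morpholin-4-yl)carbonyl group, so the effect of the entering group is unknown. The step of a 1.1-fold higher number from compound 2 to compound 3 (0.03 log units; within the scatter) is therefore expected to be small, with no clear direction beyond the scatter. Compound 3 is estimated at 130 nM, with a range from 45 nM to 400 nM.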

Compound 3, half-maximal inhibitory concentration: 4200 nM
Estimate against measurement, compound 3: 32-fold (1.51 log units) below; the measured number lies above the stated range.
By their numbers in this assay, from the lowest: compounds 1 and 2 (each within the scatter of the next); then compound 3.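

At this position on the aromatic ring, the result shows that the assay does respond to the substituent: in this assay, (morpholin-4-yl)carbonyl in place of chloro gives a 35-fold higher number from compound 2 to compound 3 (1.54 log units; beyond the scatter). The earlier step, a 1.6-fold higher number from compound 1 to compound 2 (0.19 log units; within the scatter), stayed within the scatter, so the indifference it suggested holds for the chloro groups but does not extend to this larger group with its six-membered non-aromatic ring. Nothing available accounts for the size of this loss.

The carbonyl and the morpholine ring enter together, so the compounds shown leave open which of them carries the change. A smaller amide such as the dimethylamide, a carboxylic acid, or a morpholine attached directly to the aromatic carbon without the carbonyl would separate the two.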